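Swapping the aryl ring on a thiosemicarbazone: what to expect

A few compounds are considered here, and "the series" means these few. Any claim that something is new, unique, unknown or untested is made for them only; others in the source may bear on it.

Compound 1 `CC1=CC[C@H](C(C)(C)NC(=S)NN)CC1` is the smallest member of this series, bearing the shared core with a free hydrazine end. In a functional assay on U-251 cells (Homo sapiens) for inhibition, read by sulforhodamine B assay, with a stated time of 48 h (a higher number here means a weaker inhibitor of growth, a lower number a stronger inhibitor of growth), compound 1 gives 10100 nM. Compound 2 `CC1=CC[C@H](C(C)(C)NC(=S)N/N=C/c2ccc(O)cc2)CC1` carries a 4-hydroxyphenyl group on a carbon with a double bond to nitrogen. In this assay compound 2 reaches only > 100000 nM, which is a limit of the measurement and not a number. Compound 3 `CC1=CC[C@H](C(C)(C)NC(=S)N/N=C/c2ccc(N(C)C)cc2)CC1` has a dimethylamino group in place of the hydroxy group on an aromatic carbon. In this assay compound 3 also stops at > 100000 nM, again a limit. The step that the two limits leave unreadable from compound 2 to compound 3 therefore cannot be read. Compound 4 `CC1=CC[C@H](C(C)(C)NC(=S)N/N=C/c2cccc(Cl)c2)CC1` has not yet been measured; it differs from compound 2 by 3-chlorophenyl in place of 4-hydroxyphenyl on a carbon with a double bond to nitrogen. For the measured compounds named here, no measured step bears directly on this change, and because the limit of > 100000 nM in this assay, at which 2 of the 3 values shown sit, the one comparison between aryl-bearing compounds gives no size. Both aryl-bearing compounds sit at the limit, a pattern resting on two compounds only. Compound 4 is expected to behave like them, at an estimated 100000 nM with a range from 20000 nM to 400000 nM. The implied step a number no higher from compound 2 to compound 4 (the limit leaves the size open) is expected to show no readable change.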

Compound 4, concentration for total growth inhibition: 35800 nM
Compound 4: middle estimate off by 2.8-fold (0.45 log units), on the high side; the range from low to high includes it.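

The change from 4-hydroxyphenyl to 3-chlorophenyl on the carbon with a double bond to nitrogen gives the first readable result for an aryl change at this position in this assay: an at least 2.7-fold lower number from compound 2 to compound 4 (0.44 log units; beyond the scatter). This shows that an aryl group here does not have to leave the value at the limit of the assay, and that the choice of aryl group can change the read-out by more than the usual scatter. Going by these compounds, the true size of this step stays open, and only its lower bound is known, because compound 2 has a limit and not a number of its own: the limit of > 100000 nM in this assay, at which 2 of the 4 values shown sit.

The change alters two things at once, replacing the hydroxy group with a chlorine and moving the substituent to another ring position, so the compounds shown cannot separate these two contributions. A 3-hydroxyphenyl group would keep the new ring position with the old substituent, while a 3-bromophenyl or 3-methoxyphenyl group would test whether the effect is particular to chlorine.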